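The source may hold more compounds than are shown below. What is called first, only, known or untested is meant among the compounds shown, and "the series" means these compounds.

In a functional assay on the whole organism with Rattus norvegicus as the target (on this read-out higher numbers stand for an effect only at larger amounts of compound and lower numbers for an effect already at smaller amounts), three compounds have been measured:

compound 1, `CCCN(CCNC(=O)c1cc(Cl)c(N)cc1OC)Cc1ccc(Cl)cc1`, with 3 mg/kg;
compound 2, `CCCCN(CCNC(=O)c1cc(Cl)c(N)cc1OC)Cc1ccc(Cl)cc1`, with 20 mg/kg;
compound 3, `CCNc1cc(OC)c(C(=O)NC2CCN(Cc3ccccc3)C2)cc1Cl`, with 0.1 mg/kg.

Compound 2 differs from compound 1 by methyl in place of hydrogen on a saturated chain carbon, three bonds along the chain from an amine nitrogen. In this assay that change gave a 6.7-fold higher number from compound 1 to compound 2 (0.82 log units; beyond the scatter). Compound 3 has the lowest number of the three, and its gaps to compound 1 and to compound 2 both lie beyond the scatter. How the core of compound 3 differs from the core of compound 1 is not broken down here.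

The compound still to be measured is compound 4, `CCCNc1cc(OC)c(C(=O)NC2CCN(Cc3ccccc3)C2)cc1Cl`. It differs from compound 3 by methyl in place of hydrogen on a saturated chain carbon, two bonds along the chain from a nitrogen on an aromatic ring. Among the compounds with values here, this is the same kind of change as the one from compound 1 to compound 2, but the place is not the same: there the methyl entered three bonds along the chain from an amine nitrogen, here it enters two bonds along the chain from a nitrogen on an aromatic ring.

Within the data shown here, the only measured step of this kind, a 6.7-fold higher number from compound 1 to compound 2 (0.82 log units; beyond the scatter), moved the number upward by a modest amount, and the expectation for compound 4 is a step in the same direction but of less certain size. Among the measured compounds shown here, the place differs, and no measured step at that place is available. In this assay compound 4 is expected to give 0.3 mg/kg, with a range from 0.08 mg/kg to 1.2 mg/kg. This amounts to an expected step of a 3.0-fold higher number from compound 3 to compound 4 (0.48 log units; beyond the scatter), resting on compound 3 with 0.1 mg/kg as the starting point.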

Compound 4, dose for half-maximal effect: 17 mg/kg
Compound 4: middle estimate off by 57-fold (1.75 log units), on the low side; measured number outside the range, above it.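

In this assay, going from ethylamino to propylamino on the core of compound 3 gave a 170-fold higher number from compound 3 to compound 4 (2.23 log units; beyond the scatter). Methyl in place of hydrogen raised the number in both pairs, so the direction held, but the size of the step did not carry over from one core to the other: the same change on two cores in this assay, a 6.7-fold higher number (0.82 log units; beyond the scatter) from compound 1 to compound 2 and a 170-fold higher number (2.23 log units; beyond the scatter) from compound 3 to compound 4, 26-fold (1.41 log units) apart, beyond the scatter of two such steps. This shows that, in this series, the size of the step on the core of compound 1 gives no reliable measure of the step on the core of compound 3, but it does not show what sets the two steps apart, for the pairs differ in their cores and also in where the methyl enters, three bonds along the chain from an amine nitrogen in one and two bonds along the chain from a nitrogen on an aromatic ring in the other.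

The compounds shown leave open how the number would move with a butylamino or methylamino group in place of the ethylamino group of compound 3. They also leave open whether the same change at one and the same place would give steps of similar size on both cores.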